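From Propylsulfonyl to Dimethylsulfamoyl: an Expected Step

This account rests on a few compounds, and the source may have more. Where it says the series, first, only, none or still open, it means among the compounds named here.

Measured so far:
Compound 1, `CCCS(=O)(=O)Nc1cccc2c1CCCC2c1c[nH]cn1`: < 10000 nM
Compound 2, `O=S(=O)(Nc1cccc2c1CCCC2c1c[nH]cn1)c1ccc2ccccc2c1`: 214 nM

In an assay on isolated protein (Cricetulus griseus) for binding affinity to Alpha-1B adrenergic receptor (Mesocricetus auratus), read by radioligand binding (on this read-out lower numbers stand for stronger inhibition and higher numbers for weaker inhibition), compound 1 is reported only as a limit, < 10000 nM, so its place among the numbers shown is open; it sits on the limit of < 10000 nM in this assay, at which 1 of the 2 values shown sits, and nothing finer is known of it. Going by the values given here, compound 2 gives 214 nM in this assay, the only full number in the set. Compound 3, `CN(C)S(=O)(=O)Nc1cccc2c1CCCC2c1c[nH]cn1`, has not yet been measured. It differs from compound 1 in one place: dimethylamino in place of propyl on a sulfonyl sulfur. Among the compounds with values here, because compound 1 stands only on (the limit of < 10000 nM in this assay, at which 1 of the 2 values shown sits), no measured step tells how a change at the sulfonyl sulfur moves the read-out here. The author therefore expects a step that the limit leaves unreadable from compound 1 to compound 3, with no direction that can be trusted beyond the scatter, and the outcome may again be a limit. Compound 3 is estimated at 3000 nM, with a range from 500 nM to 10000 nM.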

Compound 3, inhibition constant: < 10000 nM
Compound 3 was reported as a limit; the forecaster's own chance of this, stated with the estimate: 35%; the middle value is on the limit's open side.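

In this assay compound 3 gives < 10000 nM as a limit of the assay and not a number. Going by these compounds alone, compound 1 stands on the same limit, so no step between compound 1 and compound 3 can be read: the limit of < 10000 nM in this assay, at which 2 of the 3 values shown sit. As far as these compounds go, whether dimethylamino in place of propyl on a sulfonyl sulfur moves the read-out at all stays open.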